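The source may hold more compounds than are shown below. What is called first, only, known or untested is meant among the compounds shown, and "the series" means these compounds.

The shared core appears first in compound 1 `COc1cc(OC)cc(-c2ccc3c(c2)C(CC(=O)OCC2CO2)C(C(=O)OCC2CO2)=C(N)O3)c1`. In a functional assay on HL-60 cells (Homo sapiens) for cytotoxicity, read by CellTiter-Blue, with a stated time of 48 h (a higher number here means a weaker inhibitor, a lower number a stronger inhibitor), compound 1 gives > 80000 nM, which is a limit of the assay and not a measured number, matching (the limit of > 80000 nM in this assay, at which 1 of the 3 values shown sits).

Compound 2 `CCOC(=O)CC1C(C(=O)OCC)=C(N)Oc2ccc(-c3cc(F)cc(F)c3)cc21` gives 35900 nM in this assay. Compound 3 `C#CCOC(=O)CC1C(C(=O)OCC#C)=C(N)Oc2ccc(-c3cccc(N)c3)cc21` gives 1240 nM in this assay. Of the two numbers, compound 2 stands at the higher one, and the gap down to compound 3, its nearest neighbour, lies beyond the usual scatter of the measurement.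

Compound 4 `CCOC(=O)CC1C(C(=O)OCC)=C(N)Oc2ccc(-c3ccc(N)cc3)cc21` has not yet been measured. It differs from compound 2 in a single place: 4-aminophenyl in place of 3,5-difluorophenyl on an aromatic carbon. Among the compounds with values here, compound 3, the one compound of the set with an amino group, carries the lower of the two numbers, but its esters differ as well, so no single measured step isolates the amino group. With that caveat, compound 4 is expected to be the stronger inhibitor, and the step from compound 2 to compound 4 is estimated at a 4.5-fold lower number from compound 2 to compound 4 (0.65 log units; beyond the scatter) in this assay. Compound 4 is therefore expected to give about 8000 nM in this assay, with a likely range from 2000 nM to 35000 nM.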

Compound 4, half-maximal inhibitory concentration: 22300 nM
Compound 4: middle estimate off by 2.8-fold (0.45 log units), on the low side; the measured number falls inside the stated range.
By their numbers in this assay, from the lowest: compound 3; then compounds 4 and 2 (each within the scatter of the next). At a limit, above all of these: compound 1.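

Within the data shown here, this is the first step in the set that changes one place alone: with the ethyl esters and the rest of the shared core held fixed, 4-aminophenyl in place of 3,5-difluorophenyl on the aromatic carbon gives a 1.6-fold lower number from compound 2 to compound 4 (0.21 log units; within the scatter) in this assay. At this position, then, the two aryl groups cannot be told apart in this measurement, even though they differ in their atoms and in their counts of hydrogen-bond donors and acceptors, so this exchange alone does not give a separation beyond the scatter. The measurements shown offer no evidence that bears on why this step is so small.

Compound 3, at 1240 nM, differs from compound 4 in more than one place, so the compounds shown do not settle whether its esters, the place of its amino group or the two together account for its value. Also open, on these data alone, is how the position would respond to a plain phenyl or a 4-hydroxyphenyl, and how compound 4 would respond to a carboxylic acid in place of its ethyl esters.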